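Swapping fluoro for chloro on the pendant aryl of compound 2

This account rests on a few compounds, and the source may have more. Where it says the series, first, only, none or still open, it means among the compounds named here.

The measured compounds are:
Compound 1, `O=S(=O)(c1ccc(F)c(F)c1)c1cnc2cc(F)ccc2c1-c1ccc(Cl)cc1`, gives 22 nM in a functional assay on cells for negative allosteric modulation of metabotropic glutamate receptor 5 (Homo sapiens), read by fluorescence and calcium flux, with a stated time of 20 min; on this read-out higher numbers stand for weaker inhibition and lower numbers for stronger inhibition.
Compound 2, `O=S(=O)(c1cc(Cl)cc(Cl)c1)c1cnc2cc(F)ccc2c1-c1ccc(F)cc1`, gives 25 nM.
Compound 3, `O=S(=O)(c1ccc(F)c(Cl)c1)c1cnc2cc(F)ccc2c1-c1ccc(F)cc1`, gives 21 nM.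

All three numbers lie within the usual scatter of one another, so compound 2 cannot be set apart from compound 1 or compound 3 on these figures. Compound 4, `O=S(=O)(c1cc(Cl)cc(Cl)c1)c1cnc2cc(F)ccc2c1-c1ccc(Cl)cc1`, is compound 2 with one change: chloro in place of fluoro on an aromatic carbon. Among the measured compounds shown here, the only step measured here, a 1.2-fold lower number from compound 2 to compound 3 (0.08 log units; within the scatter), alters the group on the sulfonyl sulfur, not the ring that changes in compound 4, so no measured step bears directly on this change. Compound 1 and compound 3 also differ at this ring, but in a second place too, and their values match closely. Compound 4 is therefore expected to give a step of a 1.1-fold lower number from compound 2 to compound 4 (0.04 log units; within the scatter), nothing beyond the scatter. The estimate for compound 4 is 23 nM, in the range 10 nM to 55 nM.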

Compound 4, half-maximal inhibitory concentration: 94 nM
Compound 4: the middle estimate sits 4.1-fold (0.61 log units) below what was measured; measured number outside the range, above it.
By their numbers in this assay, from the lowest: compounds 3, 1 and 2 (each within the scatter of the next); then compound 4.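

Chloro in place of fluoro at this position is not a neutral swap: with 3,5-dichlorophenyl on the sulfonyl sulfur, it gives a 3.8-fold higher number from compound 2 to compound 4 (0.58 log units; beyond the scatter) and so weaker inhibition. With 4-chlorophenyl held constant, 3,5-dichlorophenyl in place of 3,4-difluorophenyl gives a 4.3-fold higher number from compound 1 to compound 4 (0.63 log units; beyond the scatter) and also weakens inhibition, so the group on the sulfur matters here, although the sulfur change between compound 2 and compound 3 stayed within the scatter. Nothing available explains why inhibition weakens in compound 4. On these data alone, how a bromo or a methoxy would behave at this position remains open.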